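Replacing sulfamoyl with a larger non-ring group on the core

A few compounds are considered here, and "the series" means these few. Any claim that something is new, unique, unknown or untested is made for them only; others in the source may bear on it.

Of the compounds shown here, two built on a shared core have been measured in an ADME assay (liver) for metabolic stability, with Liver microsome (Rattus norvegicus) as the target, using microsomes and NADPH, with a stated time of 30 min; on this read-out higher numbers stand for fast clearance and lower numbers for slow clearance. Compound 1 `CC#C[C@H]1CN(S(=O)(=O)c2ccc(N)nc2)CCN1c1ncc(C(C)(O)C(F)(F)F)s1` gives 87 mL.min-1.g-1. Compound 2 `CC#C[C@H]1CN(S(=O)(=O)c2ccc(N)nc2)CCN1c1ccc(S(N)(=O)=O)cc1` gives 30 mL.min-1.g-1, the lower of the two numbers; the gap up to compound 1 lies beyond the usual scatter of repeated measurements of this kind. Compound 3 `CC#C[C@H]1CN(S(=O)(=O)c2ccc(N)nc2)CCN1c1ccc(C(O)(CC#N)C(F)(F)F)cc1` has not yet been measured. It differs from compound 2 in one place: a group of 9 heavy atoms (4 carbon, 1 nitrogen, 1 oxygen, 3 fluorine; no ring) in place of a group of 4 heavy atoms (1 nitrogen, 2 oxygen, 1 sulfur; no ring), on an aromatic carbon. Going by the values given here, no measured pair differs in just this way, so the size of the step can only be judged from the two numbers at hand. Among the compounds with values here, the group entering compound 3 resembles the one carried by compound 1, which gives 87 mL.min-1.g-1, and for that reason the step in this assay is expected to run upward, toward faster clearance, by a moderate amount a 1.8-fold higher number from compound 2 to compound 3 (0.26 log units; within the scatter), beyond the scatter but short of a large shift. Compound 3 is therefore estimated to give 55 mL.min-1.g-1, with a likely range from 25 mL.min-1.g-1 to 120 mL.min-1.g-1.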

Compound 3, intrinsic clearance in microsomes: 57 mL.min-1.g-1
Compound 3: middle estimate off by 1.0-fold (0.02 log units), on the low side; measured number inside the range.
By their numbers in this assay, from the lowest: compounds 2, 3 and 1 (each within the scatter of the next, the first and the last beyond it).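

In this assay, exchanging sulfamoyl for the larger non-ring group on the aromatic carbon, para to a large group, gives a 1.9-fold higher number from compound 2 to compound 3 (0.28 log units; within the scatter), the only step shown so far in which two measured compounds differ in one place. The entering group has 9 heavy atoms against 4 for sulfamoyl, brings in fluorine and a triple bond, and loses the sulfur, while the counts of hydrogen-bond donors and acceptors stay the same; even so, this read-out does not separate compound 2 from compound 3 beyond the usual scatter. Nothing measured here offers an explanation for this result.

Going by these compounds, with a single exchange at this position, it remains open which part of the entering group matters, for instance whether removing the nitrile or replacing the hydroxyl with a hydrogen would leave the clearance within the scatter of compound 3. On these data alone, it is equally open whether an amine or a carboxylic acid on the same aromatic carbon would give a number close to those of compound 2 and compound 3, or one clearly apart from them.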